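The source may hold more compounds than are shown below. What is called first, only, known or untested is meant among the compounds shown, and "the series" means these compounds.

Two measured analogues share the same core and differ only in the methoxyphenyl group on the amine nitrogen. Compound 1 `COc1ccc(Nc2nc(Oc3cccc(NC(=O)C=C(C)C)c3)c3sccc3n2)cc1` gives 18100 nM in a functional assay on A549 cells (Homo sapiens) for inhibition, read by MTT assay, with a stated time of 72 h; on this read-out higher numbers stand for weaker inhibition and lower numbers for stronger inhibition. Compound 2 `COc1cccc(Nc2nc(Oc3cccc(NC(=O)C=C(C)C)c3)c3sccc3n2)c1` gives 27700 nM in this assay. The single measured step, a 1.5-fold higher number from compound 1 to compound 2 (0.18 log units; within the scatter), does not exceed the scatter, so on the two numbers shown compound 2 and compound 1 cannot be separated and no ranking is claimed. Compound 3 `COc1ccc(Nc2nc(Oc3cccc(NC(=O)C=C(C)C)c3)c3sccc3n2)cn1` differs from compound 2 by 6-methoxypyridin-3-yl in place of 3-methoxyphenyl on a nitrogen on an aromatic ring. Within the data shown here, no measured step exchanges a carbon-only ring for one with a ring nitrogen, so the only reference is that this assay was flat across the methoxy shift. The step of a 1.1-fold lower number from compound 2 to compound 3 (0.04 log units; within the scatter) is therefore expected to be small, because a 1.5-fold higher number from compound 1 to compound 2 (0.18 log units; within the scatter) stayed within the scatter, with no firm direction. Compound 3 is estimated at 25000 nM, range 8000 nM to 80000 nM.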

Compound 3, half-maximal inhibitory concentration: 40100 nM
For compound 3 the middle estimate is 1.6-fold (0.21 log units) below the measured one; the measured number falls inside the stated range.
By their numbers in this assay, from the lowest: compounds 1, 2 and 3 (each within the scatter of the next, the first and the last beyond it).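

In this assay the exchange of a carbon-only ring for a ring holding one nitrogen gives a 1.4-fold higher number from compound 2 to compound 3 (0.16 log units; within the scatter) and so, on its own, does not separate these two aryl groups on the aromatic amine nitrogen. Set against the 4-methoxyphenyl group, however, 6-methoxypyridin-3-yl gives a 2.2-fold higher number from compound 1 to compound 3 (0.35 log units; beyond the scatter) and thus the first step in this short series that clears the scatter, a modest one towards weaker inhibition. Nothing at hand bears on the reason for this step.

The compounds shown leave open whether the methoxy group matters at all on this nitrogen, which an unsubstituted phenyl or a 4-aminophenyl group would test. Also open, going by these compounds, is whether the 3-methylbut-2-enamide chain on the shared core tolerates change, for instance a plain acrylamide.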